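A few compounds are considered here, and "the series" means these few. Any claim that something is new, unique, unknown or untested is made for them only; others in the source may bear on it.

In a functional assay on ECa-109 cells for antiproliferative activity against ECa-109 cell line (Homo sapiens), read by MTT assay, with a stated time of 48 h (on this read-out higher numbers stand for weaker inhibition and lower numbers for stronger inhibition), three compounds built on one shared core have been measured. Compound 1 `Clc1ccc(Cn2cc(CSc3nnc(-c4ccccc4)c(-c4ccccc4)n3)nn2)cc1` gives 24200 nM. Compound 2 `Cc1ccc(Cn2cc(CSc3nnc(-c4ccccc4)c(-c4ccccc4)n3)nn2)cc1` gives 12400 nM. Compound 3 `c1ccc(Cn2cc(Cc3nnc(-c4ccccc4)c(-c4ccccc4)n3)nn2)cc1` gives 11100 nM. On the bare numbers compound 2 stands second highest of the three, with compound 3 nearest and compound 1 furthest, but both gaps lie inside the scatter, so the three are not separated. For the measured compounds named here, the only single-point step among the measured compounds is a 2.0-fold lower number from compound 1 to compound 2 (0.29 log units; within the scatter), an exchange on an aromatic carbon that did not move the read-out beyond the scatter.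

Compound 4 `COc1ccc(Cn2cc(CSc3nnc(-c4ccccc4)c(-c4ccccc4)n3)nn2)cc1` differs from compound 2 by methoxy in place of methyl on an aromatic carbon. Going by the values given here, the one measured comparison that bears on it, the exchange on the same aromatic carbon from compound 1 to compound 2, stayed within the scatter, so no step beyond the scatter is expected in this assay in either direction. Compound 4 is therefore expected to give about 12000 nM, with a range from 5000 nM to 30000 nM. The step this expectation implies is a 1.0-fold lower number from compound 2 to compound 4 (0.01 log units; within the scatter).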

Compound 4, half-maximal inhibitory concentration: 28400 nM
For compound 4 the middle estimate is 2.4-fold (0.37 log units) below the measured one, and the stated range covers the measured number.
By their numbers in this assay, from the lowest: compounds 3, 2, 1 and 4 (each within the scatter of the next, the first and the last beyond it).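

For the compounds shown here, on the six-membered aromatic ring, para to a large group, methoxy in place of methyl gave the first step beyond the scatter in this assay, a modest 2.3-fold higher number from compound 2 to compound 4 (0.36 log units; beyond the scatter), so this position is not wholly indifferent to the group it carries. Methoxy in place of chloro, however, gave only a 1.2-fold higher number from compound 1 to compound 4 (0.07 log units; within the scatter), which leaves compound 4 and compound 1 unseparated and shows that only one of the two exchanges to methoxy clears the scatter. Nothing available accounts for the step from methyl to methoxy.

On these data alone, it remains open whether a hydroxyl, an amine or a carboxylic acid on the same carbon would shift the read-out further in either direction. As far as these compounds go, whether the step from compound 2 to compound 4 would hold in another cell line also remains open.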